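The source may hold more compounds than are shown below. What is called first, only, known or untested is meant among the compounds shown, and "the series" means these compounds.

Series notes. Among the compounds with values here, compound 1 `O=[N+]([O-])c1ccc(-c2noc(Cc3c[nH]c4ccccc34)n2)cc1` is the first member. In an ADME assay on cells (Splenocyte, Mus musculus, strain BALB/c) for cytotoxicity, read by CCK-8 assay, with a stated time of 48 h (on this read-out lower numbers stand for higher toxicity in this test and higher numbers for lower toxicity in this test), compound 1 gives > 50000 nM, which is a limit of this assay rather than a number. Compound 2 `COc1cccc(-c2nc(Cc3c[nH]c4ccccc34)no2)c1` carries one methoxy group. In this assay, within the data shown here, compound 2 gives 18400 nM, the only number among the three values shown. Compound 3 `COc1cc(OC)cc(-c2nc(Cc3c[nH]c4ccccc34)no2)c1` carries two methoxy groups. In this assay compound 3 gives > 50000 nM, a limit. Among the measured compounds shown here, the single measured step between compounds differing in one place, an at least 2.7-fold higher number from compound 2 to compound 3 (0.43 log units; beyond the scatter), runs toward lower toxicity, and the limit of > 50000 nM in this assay, at which 2 of the 3 values shown sit, marks where two of the three values sit.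

Compound 4 `COc1ccc(Br)c(-c2nc(Cc3c[nH]c4ccccc34)no2)c1` differs from compound 2 by bromo in place of hydrogen on an aromatic carbon. For the measured compounds named here, no measured step involves a bromo group, so the step to compound 3 bears on compound 4 only as a sign that one added group on this ring moved this assay by an at least modest amount. A shift of that size or none beyond the scatter is expected, so compound 4 is estimated at 25000 nM (range 9000 nM to 60000 nM). The expected step is a 1.4-fold higher number from compound 2 to compound 4 (0.13 log units; within the scatter).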

Compound 4, half-maximal cytotoxic concentration: 33600 nM
The estimate for compound 4 lay 1.3-fold (0.13 log units) below the measured number; measured number inside the range.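

In this assay, bromo on this aromatic carbon, ortho to a large group and para to a methoxy group, gives a 1.8-fold higher number from compound 2 to compound 4 (0.26 log units; within the scatter), so this position takes a single added bromine atom with no change that can be told from the scatter. The earlier step, an at least 2.7-fold higher number from compound 2 to compound 3 (0.43 log units; beyond the scatter), came from a methoxy group and lay beyond the scatter, so one added group on this ring does not always shift the read-out by that much. Bromo at this place also does not bring the read-out to a limit: the limit of > 50000 nM in this assay, at which 2 of the 4 values shown sit.

The compounds shown leave open whether an amine or a carboxylic acid at this same place would shift the read-out beyond the scatter. As far as these compounds go, how bromo behaves on this ring without the methoxy group also stays open.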